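Pyridine to piperidine on the amide of compound 1

The compounds below may be only part of what the source reports. "The series", "measured", "known", "first", "only" and "open" are said of these compounds alone.

Measured compounds:
compound 1, `CC(C)(C)C(=O)N1Cc2c(NC(=O)c3ccncc3)n[nH]c2C1(C)C`: in a physicochemical assay for solubility, at pH 7 (a higher number here means a more soluble compound, a lower number a less soluble compound), compound 1 gives 205000 nM.
compound 2, `CC1(C)c2[nH]nc(NC(=O)c3ccc(F)cc3)c2CN1C(=O)C1CCN(C2CC2)CC1`: in this assay compound 2 reaches only the limit > 225000 nM.
compound 3, `CN1CCC(C(=O)N2Cc3c(NC(=O)c4ccncc4)n[nH]c3C2(C)C)CC1`: in this assay compound 3 likewise reaches only the limit > 225000 nM.

Among the compounds with values here, compound 1 is the only member of the set with an actual number in this assay; the other two stop at a limit, (the limit of > 225000 nM in this assay, at which 2 of the 3 values shown sit). Within the data shown here, the one measured step that changes a single place, an at least 1.0-fold higher number from compound 1 to compound 3 (0.04 log units; that floor lies within the scatter), runs into that limit, so only its floor is known, and that floor lies within the scatter.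

Compound 4, `CC(C)(C)C(=O)N1Cc2c(NC(=O)C3CCNCC3)n[nH]c2C1(C)C`, differs from compound 1 in one place: piperidin-4-yl in place of pyridin-4-yl on a carbonyl carbon. A piperidin-4-yl ring also enters in compound 3, there carrying a methyl group and at a different carbonyl carbon, and that step did not lower the number.

Among the measured compounds shown here, the step from compound 1 to compound 3 is the only measured guide; it points upward or flat, not down, and its size cannot be resolved beyond the scatter. Compound 4 is therefore expected to give 230000 nM in this assay, within 140000 nM to 400000 nM. That estimate means a step of a 1.1-fold higher number from compound 1 to compound 4 (0.05 log units; within the scatter), expected to sit near the edge of the scatter, with the measurement likely to end at the limit rather than at a number.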

Compound 4, solubility: > 225000 nM
Compound 4: only a limit was reported; the forecaster's own chance of this, stated with the estimate: 60%; the middle value does not contradict the limit.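

In this assay, compound 4 reaches only a limit, > 225000 nM. The earlier single-place step changed the group on the other carbonyl carbon, whereas this one exchanges the six-membered aromatic pyridin-4-yl for the non-aromatic piperidin-4-yl, which carries 1 hydrogen-bond donor where pyridin-4-yl carries 0; it gives an at least 1.0-fold higher number from compound 1 to compound 4 (0.04 log units; that floor lies within the scatter), so only a floor is known and the true size of the step stays unresolved. The read-out at this position now ends in the same way as the change on the other carbonyl carbon, and neither place gives a measured number to compare: the limit of > 225000 nM in this assay, at which 3 of the 4 values shown sit.

Still open, as far as these compounds go, is the real size of the step from pyridin-4-yl to piperidin-4-yl, and whether the ring nitrogen of the piperidin-4-yl group matters at all, since a cyclohexyl ring on the same carbonyl carbon would separate the ring shape from that nitrogen. A carboxylic acid or a longer alkyl chain at this place could also show whether any group here gives a number in this assay rather than a limit.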